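The source may hold more compounds than are shown below. What is called first, only, known or untested is meant among the compounds shown, and "the series" means these compounds.

Three compounds built on a shared core were tested in a functional assay on HEK293 cells (Homo sapiens) for cytotoxicity; on this read-out higher numbers stand for lower toxicity in this test and lower numbers for higher toxicity in this test: compound 1, `COc1ccc([C@H]2CC(=O)N(c3cccc(O)c3)C2)cc1OC1CCCC1`, compound 2, `COc1ccc([C@H]2CC(=O)N(c3cccc(N(C)C)c3)C2)cc1OC1CCCC1`, and compound 3, `COc1ccc([C@H]2CC(=O)N(c3ccc(N)cc3)C2)cc1OC1CCCC1`. For compound 1 the result is a limit of the assay, > 10000 nM. For compound 2 the result is likewise a limit, > 10000 nM. For compound 3 the result is again a limit, > 10000 nM. The steps a step that the two limits leave unreadable from compound 1 to compound 2, a step that the two limits leave unreadable from compound 1 to compound 3 and a step that the two limits leave unreadable from compound 2 to compound 3 therefore cannot be read, because of the limit of > 10000 nM in this assay, at which 3 of the 3 values shown sit. Compound 4, `COc1ccc([C@H]2CC(=O)N(c3cccc(C(F)(F)F)c3)C2)cc1OC1CCCC1`, has not yet been tested in this assay. It differs from compound 2 in one place: trifluoromethyl in place of dimethylamino on an aromatic carbon. Of the measured steps, the two that start from compound 2 bear on this change, and neither gives a readable size; so no step beyond the scatter is expected in this assay, and a further limit is the likeliest outcome. The step from compound 2 to compound 4 is estimated as a step that the limit leaves unreadable from compound 2 to compound 4. Compound 4 is thus expected to give about 20000 nM in this assay, within 7000 nM to 60000 nM.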

Compound 4, half-maximal cytotoxic concentration: > 10000 nM
Compound 4: only a limit was reported; the forecaster's own chance of this, stated with the estimate: 80%; the middle value is on the limit's open side.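

Compound 4 also gives only a limit in this assay, so no step between it and compound 1, compound 2 or compound 3 can be read, because all four values rest at the same limit: the limit of > 10000 nM in this assay, at which 4 of the 4 values shown sit.

The compounds shown leave open whether any of these changes alters cytotoxicity in this assay at all.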